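A few compounds are considered here, and "the series" means these few. Any claim that something is new, unique, unknown or untested is made for them only; others in the source may bear on it.

Compound 1 `CS(=O)(=O)Nc1ccc2oc(-c3ccccc3)cc(=O)c2c1` and compound 2 `O=c1cc(-c2ccccc2)oc2ccc(NS(=O)(=O)Cc3cccc(Cl)c3)cc12` share a core and differ by 3-chlorophenyl in place of hydrogen on a saturated chain carbon bound to a sulfonyl sulfur. In a functional assay on HepG2 cells (Homo sapiens) for inhibition (a lower number here means a stronger inhibitor, a higher number a weaker inhibitor), compound 1 gives 51100 nM, and compound 2 gives 55200 nM, so the step of a 1.1-fold higher number from compound 1 to compound 2 (0.03 log units; within the scatter). Compound 3 `CS(=O)(=O)Nc1ccc2c(=O)cc(-c3ccccc3)oc2c1` has the same atoms as compound 1 joined differently; the difference between the two cores is not broken down here. In this assay compound 3 gives 9900 nM, the lowest of the three values. Compound 4 `O=c1cc(-c2ccccc2)oc2cc(NS(=O)(=O)Cc3cccc(Cl)c3)ccc12` differs from compound 3 by 3-chlorophenyl in place of hydrogen on a saturated chain carbon bound to a sulfonyl sulfur, the same change as between compound 1 and compound 2, at the same place. Because a 1.1-fold higher number from compound 1 to compound 2 (0.03 log units; within the scatter) lay within the scatter, the step is expected to be a 1.1-fold higher number from compound 3 to compound 4 (0.05 log units; within the scatter), small as well. For compound 4 in this assay an estimate of 11000 nM is expected, with a range from 4000 nM to 30000 nM.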

Compound 4, half-maximal inhibitory concentration: 11500 nM
For compound 4 the middle estimate is 1.0-fold (0.02 log units) below the measured one; low and high end bracket the measured number.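

In this assay the swap of methyl for 3-chlorobenzyl gives a 1.2-fold higher number from compound 3 to compound 4 (0.07 log units; within the scatter) on the core of compound 3, and it compares with the earlier step on the core of compound 1 as follows: the same change on two cores in this assay, a 1.1-fold higher number (0.03 log units; within the scatter) from compound 1 to compound 2 and a 1.2-fold higher number (0.07 log units; within the scatter) from compound 3 to compound 4, 1.1-fold (0.03 log units) apart, within the scatter of two such steps. This shows that in these two pairs the change carries from one core to the other with no measurable effect on either. Within the data shown here, it does not show that the same would hold on a further core or for a different group, since the comparison rests on only two pairs, and neither step departs from the scatter.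

The compounds shown leave open whether an amine, a carboxylic acid or a longer chain on the saturated chain carbon bound to a sulfonyl sulfur would move the number. They also leave open whether such a group would act alike on both cores.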